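Ethoxy in place of methoxy on a benzamido-bearing core

The source may report more compounds than this note shows. Statements on the series, on what has been measured and on what is new or still open speak of the compounds shown alone.

Compound 3 `COc1ccc(NCN2C(=O)c3cccc(NC(=O)c4ccccc4)c3C2=O)cc1` is measured in an assay on isolated protein for inhibition of ribosomal protein S6 kinase alpha-2 (Homo sapiens), read by fluorescence, with a stated time of 20 min (on this read-out higher numbers stand for weaker inhibition and lower numbers for stronger inhibition), where compound 3 gives 990 nM. The parent compound 1 `COc1ccc(NCN2C(=O)c3ccccc3C2=O)cc1` gives 470 nM, and the step of a 2.1-fold higher number from compound 1 to compound 3 (0.32 log units; beyond the scatter) sets compound 3 apart from compound 1. Compound 2 `CCOc1ccc(NCN2C(=O)c3ccccc3C2=O)cc1` gives 590 nM, and the numbers of compound 2 and compound 3 lie within the scatter of each other, so nothing separates those two.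

Compound 4 `CCOc1ccc(NCN2C(=O)c3cccc(NC(=O)c4ccccc4)c3C2=O)cc1` differs from compound 3 in one place: methyl in place of hydrogen on a saturated chain carbon bound to an oxygen on an aromatic ring. The same change has been made once before, on the core without the benzamido group, as the step of a 1.3-fold higher number from compound 1 to compound 2 (0.10 log units; within the scatter), which stayed within the scatter. Among the measured compounds shown here, no other measured pair speaks to this change. On that single precedent, the step from compound 3 to compound 4 in this assay is expected to be small, if anything a slightly higher number, and is not expected to reach beyond the scatter.

Compound 4 is therefore estimated at 1200 nM, with a range from 600 nM to 2500 nM. The expected step is a 1.2-fold higher number from compound 3 to compound 4 (0.08 log units; within the scatter).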

Compound 4, half-maximal inhibitory concentration: 1340 nM
Compound 4: middle estimate off by 1.1-fold (0.05 log units), on the low side; the measured number falls inside the stated range.
By their numbers in this assay, from the lowest: compounds 1, 2, 3 and 4 (each within the scatter of the next, the first and the last beyond it).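

In this assay, the change from methoxy to ethoxy now has a reading on the benzamido-bearing core as well, a 1.4-fold higher number from compound 3 to compound 4 (0.13 log units; within the scatter), so this added methyl stays within the scatter on both cores, and the two steps agree: the same change on two cores in this assay, a 1.3-fold higher number (0.10 log units; within the scatter) from compound 1 to compound 2 and a 1.4-fold higher number (0.13 log units; within the scatter) from compound 3 to compound 4, 1.1-fold (0.03 log units) apart, within the scatter of two such steps The benzamido group, until now read only with the methoxy compounds, now also has a reading with ethoxy, a 2.3-fold higher number from compound 2 to compound 4 (0.36 log units; beyond the scatter), a modest step beyond the scatter that matches the earlier one: the same change on two cores in this assay, a 2.1-fold higher number (0.32 log units; beyond the scatter) from compound 1 to compound 3 and a 2.3-fold higher number (0.36 log units; beyond the scatter) from compound 2 to compound 4, 1.1-fold (0.03 log units) apart, within the scatter of two such steps Across these four compounds, each change reads the same on either core, so the step of neither depends on the other, and of the two changes only benzamido in place of hydrogen moves the number beyond the scatter.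

The compounds shown leave open whether a longer chain, such as propoxy or butoxy, in place of ethoxy would also stay within the scatter. They also leave open what a smaller acetamido group or a free amine would do on the aromatic carbon that carries the benzamido group, and whether either would give a step of the same size.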